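This account rests on a few compounds, and the source may have more. Where it says the series, first, only, none or still open, it means among the compounds named here.

Measured so far:
- compound 1 `COc1cccc(C(=O)Oc2cc3c(cc2C)[C@@H](C(C)C)CC=C3C)c1` — "not active" (no number reported)
- compound 2 `Cc1cc2c(C(C)C)ccc(C)c2cc1OC(=O)c1ccc(C(F)(F)F)cc1` — 55.6%
- compound 3 `CC1=CC[C@H](C(C)C)c2cc(C)c(OC(=O)c3cccc(C(F)(F)F)c3)cc21` — 15%

In a functional assay on HCT-15 cells (Homo sapiens) for antiproliferative activity, read by sulforhodamine B assay, with a stated time of 48 h, tested at 50 uM (on this read-out lower numbers stand for less inhibition and higher numbers for more inhibition at the one concentration tested (going by the name of the read-out)), compound 2 gives the highest of the two numbers reported. Compound 3 sits a number well below it, beyond the usual scatter, and compound 1 carries no single number at all, being reported as not active. Compound 4 `COc1ccc(C(=O)Oc2cc3c(C)ccc(C(C)C)c3cc2C)cc1` has not yet been measured. It shares the core of compound 2 and differs from it only in the ester-bearing ring: methoxy in place of trifluoromethyl on an aromatic carbon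

Among the measured compounds shown here, no step between measured compounds with this exact change is available. What there is points downward: compound 1, which carries a methoxy on its ester ring though on a different core, is reported as not active, while the trifluoromethyl analogues compound 2 and compound 3 both return numbers. On that basis a drop of moderate size in this assay is expected from compound 2 to compound 4, a number 25.6 percentage points lower from compound 2 to compound 4 (beyond the scatter), with a real chance that only a limit is reported. Compound 4 is estimated at 30%, within 8% to 55%.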

Compound 4, a percentage reported as inhibition, at one concentration (the size of the read-out at that concentration, not a potency): 84%
The estimate for compound 4 lay 54 percentage points below the measured number; measured number above the stated range.
By their numbers in this assay, from the lowest: compound 3; then compound 2; then compound 4.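

In this assay, among the compounds shown here, methoxy in place of trifluoromethyl on an aromatic carbon, para to a large group, gives a number 28.4 percentage points higher from compound 2 to compound 4 (beyond the scatter) as the only step so far between measured compounds that differ in one place. This position on the ester-bearing ring therefore accepts methoxy on the shared core, and a single exchange there moves the read-out beyond the scatter. No measured property bears on this step, and it stands without a stated cause.

On these data alone, whether other groups at this place, such as an amine or a carboxylic acid, raise or lower the number remains open. Also open is whether the same exchange on the core of compound 3 moves the read-out in the same direction, and whether the step reflects potency, since only one concentration is shown.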